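Ethyl on the Distal Phenyl of a Fatty Acid Receptor Agonist

A few compounds are considered here, and "the series" means these few. Any claim that something is new, unique, unknown or untested is made for them only; others in the source may bear on it.

Compound 1 `O=C(O)CCc1ccc(OCc2nc(-c3ccccc3)no2)c(Cl)c1` gives 13100 nM in a functional assay on CHO cells for agonist activity at Free fatty acid receptor 1 (Homo sapiens), read by FLIPR and calcium flux, in the presence of a further agent that is not named here; a higher number here means that more compound is needed for the effect, a lower number that less compound is needed.
Compound 2 `O=C(O)CCc1ccc(OCc2nc(-c3ccccc3)no2)cc1` gives 1130 nM in this assay.
Compound 3 `CC(Oc1ccc(CCC(=O)O)cc1)c1nc(-c2ccccc2)no1` gives 2390 nM in this assay.

Compound 2 stands lowest of the three numbers in this assay; its nearest neighbour is compound 3, at a 2.1-fold higher number from compound 2 to compound 3 (0.33 log units; beyond the scatter), and the furthest is compound 1, at a 12-fold lower number from compound 1 to compound 2 (1.06 log units; beyond the scatter). Compound 4 `CCc1ccc(-c2noc(COc3ccc(CCC(=O)O)cc3)n2)cc1` is not yet measured. It differs from compound 2 in one place: ethyl in place of hydrogen on an aromatic carbon.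

Neither measured step touches the same place. The step from compound 1 to compound 2 removes chloro from the central aromatic ring, and the step from compound 2 to compound 3 adds methyl to the saturated chain carbon; the phenyl ring on the far side of the shared core has so far not been varied. The two measured steps only show that changes away from the acid chain can move the number by a modest to large amount in either direction. Without a direct precedent, compound 4 is expected to stay close to compound 2, with a step of a 1.4-fold lower number from compound 2 to compound 4 (0.15 log units; within the scatter) that may fall within the scatter. Compound 4 is therefore estimated at 800 nM in this assay, within a range of 250 nM to 3000 nM.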

Compound 4, half-maximal effective concentration: 210 nM
For compound 4 the middle estimate is 3.8-fold (0.58 log units) above the measured one; measured number below the stated range.
By their numbers in this assay, from the lowest: compound 4; then compound 2; then compound 3; then compound 1.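

Among the compounds shown here, the phenyl ring on the far side of the shared core is the one part that compound 1, compound 2 and compound 3 left unchanged, and it proves sensitive: going from phenyl to 4-ethylphenyl gives a 5.4-fold lower number from compound 2 to compound 4 (0.73 log units; beyond the scatter) in this assay. Starting from compound 2, added chloro and added methyl elsewhere both go with higher numbers, whereas this added ethyl goes with a lower one. Nothing measured here accounts for the size of this step.

As far as these compounds go, it remains open whether ethyl itself matters, since a longer chain such as propyl or a methoxy group at the same place could give a different number. From the compounds shown here alone, it is also open whether the ethyl step would hold alongside the added methyl of compound 3.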